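From bromo to methoxy on the shared core

The compounds below may be only part of what the source reports. "The series", "measured", "known", "first", "only" and "open" are said of these compounds alone.

compound 1, `CC1CN(c2cccc(F)n2)NC(=O)N1`: 6000 nM
compound 2, `CC1CN(c2cccc(Br)n2)NC(=O)N1`: 3100 nM

Both compounds were measured in a functional assay on cells for inhibition of Polyunsaturated fatty acid 5-lipoxygenase (Homo sapiens); a higher number here means a weaker inhibitor, a lower number a stronger inhibitor. Compound 2 gives the smaller of the two numbers, yet the step of a 1.9-fold lower number from compound 1 to compound 2 (0.29 log units; within the scatter) stays within the scatter, so the pair cannot be told apart. Compound 3, `COc1cccc(N2CC(C)NC(=O)N2)n1`, carries methoxy in place of bromo on an aromatic carbon. Going by the values given here, the only measured step, a halogen swap at the same position, was within the scatter, and no measured compound bears a methoxy group there, so no guidance exists for this change. A step of a 1.3-fold higher number from compound 2 to compound 3 (0.11 log units; within the scatter) is therefore expected, no larger than the scatter. Compound 3 is estimated at 4000 nM, in the range 1500 nM to 12000 nM.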

Compound 3, half-maximal inhibitory concentration: 7100 nM
The estimate for compound 3 lay 1.8-fold (0.25 log units) below the measured number; low and high end bracket the measured number.
By their numbers in this assay, from the lowest: compounds 2, 1 and 3 (each within the scatter of the next, the first and the last beyond it).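

In this assay, the aromatic carbon next to the ring nitrogen does respond to a change of group: methoxy in place of bromo gives a 2.3-fold higher number from compound 2 to compound 3 (0.36 log units; beyond the scatter) and this modest step is the only one here beyond the scatter. Methoxy in place of fluoro gives a 1.2-fold higher number from compound 1 to compound 3 (0.07 log units; within the scatter) and so these two compounds cannot be told apart. No measurement here offers a reason for the difference between bromo and methoxy.

On these data alone, whether an amine, a carboxylic acid or a longer chain on this carbon would shift the number remains open. Also open, as far as these compounds go, is whether any group here could give a much lower number.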